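A few compounds are considered here, and "the series" means these few. Any claim that something is new, unique, unknown or untested is made for them only; others in the source may bear on it.

Compound 1 `COc1cc(C(C)=O)ccc1OCCCN1CCC(C(c2ccc(F)cc2)c2ccc(F)cc2)CC1` stands tightest of the three measured compounds in a functional assay (aorta) with Oryctolagus cuniculus as the target; on this read-out lower numbers stand for tighter binding and higher numbers for weaker binding: compound 1 gives 1.59 nM. Compound 2 `COc1cc(C(C)=O)ccc1OCCCN1CCC(C(c2ccccc2)c2ccc(F)cc2)CC1` gives 6.31 nM, and compound 3 `COc1cc(C(C)=O)ccc1OCCCN1CCC(C(N)(c2ccc(F)cc2)c2ccc(F)cc2)CC1` gives 31.6 nM. Both steps away from compound 1 lie beyond the scatter: a 4.0-fold higher number from compound 1 to compound 2 (0.60 log units; beyond the scatter), and a 20-fold higher number from compound 1 to compound 3 (1.30 log units; beyond the scatter).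

Compound 4 `COc1ccccc1OCCCN1CCC(C(c2ccc(F)cc2)c2ccc(F)cc2)CC1` differs from compound 1 elsewhere in the molecule. hydrogen in place of acetyl on an aromatic carbon Neither measured step bears on this change. The steps to compound 2 and to compound 3 both concern the part of the molecule that carries the two aromatic rings and the saturated chain carbon between them, while the 4-acetyl-2-methoxyphenoxy group is kept unchanged in every measured compound. Among the compounds with values here, no measured step therefore tells how this assay answers replacement of the acetyl group by hydrogen. With no direct comparison available, the expectation for compound 4 is a modest weakening, a 3.1-fold higher number from compound 1 to compound 4 (0.50 log units; beyond the scatter), held with wide uncertainty in both directions. Compound 4 is thus expected to give 5 nM in this assay, with a range from 1.5 nM to 20 nM.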

Compound 4, dissociation constant: 2.51 nM
Beside the measured number, compound 4's estimate is 2.0-fold (0.30 log units) above it; measured number inside the range.
By their numbers in this assay, from the lowest: compounds 1 and 4 (each within the scatter of the next); then compound 2; then compound 3.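

Within the data shown here, this is the first step that touches the ring bearing the methoxy group, and in this assay hydrogen in place of acetyl gives a 1.6-fold higher number from compound 1 to compound 4 (0.20 log units; within the scatter), so the read-out does not separate the two compounds. On the core of compound 1, a number in this low range therefore does not depend on the acetyl group, and this site para to the large group accepts the loss of all its heavy atoms, whereas changes at the other end of the molecule give a 4.0-fold higher number from compound 1 to compound 2 (0.60 log units; beyond the scatter) and a 20-fold higher number from compound 1 to compound 3 (1.30 log units; beyond the scatter). Nothing available here accounts for this outcome.

The compounds shown leave open how a larger or different group at this site, such as a carboxylic acid, an amine or a nitrile, would read in this assay, since only acetyl and hydrogen appear there. They also leave open whether hydrogen in place of acetyl would read the same way on the cores of compound 2 and compound 3, and how the methoxy group on the same ring contributes.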